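Solubility outlook for an indoline analogue of compound 3

A few compounds are considered here, and "the series" means these few. Any claim that something is new, unique, unknown or untested is made for them only; others in the source may bear on it.

Compound 3 `CNC(=O)c1cc(C(=O)NC2CC2)cn(CC2CCCCC2)c1=O` gives, in a physicochemical assay for solubility (a lower number here means a less soluble compound, a higher number a more soluble compound), only a limit, >= 148 ug/mL. Compound 1 `CNC(=O)c1cc(C(=O)NC2CC2)cn(Cc2cccc(OC)c2)c1=O` gives a plain number in this assay, 79 ug/mL. Compound 2 `CNC(=O)c1cc(C(=O)NC2CC2)cn(Cc2ccc3nc[nH]c3c2)c1=O` also sits at a limit, >= 163 ug/mL. The change to compound 4 `CNC(=O)c1cc(C(=O)NC2CC2)cn(Cc2cccc3c2CCN3)c1=O` is 2,3-dihydro-1H-indol-4-yl in place of cyclohexyl on a saturated chain carbon bound to an aromatic nitrogen. Going by the values given here, two measured steps bear on it, an at least 1.8-fold higher number from compound 1 to compound 3 (0.27 log units; that floor lies within the scatter) and an at least 2.0-fold higher number from compound 1 to compound 2 (0.31 log units; beyond the scatter), both starting from compound 1 and both ending at a limit, and a step that the two limits leave unreadable from compound 2 to compound 3. The numbers therefore say only that the aromatic and the saturated substituents in this assay both reach a floor. For compound 4 the expected step is an at least 1.1-fold lower number from compound 3 to compound 4 (0.05 log units; that floor lies within the scatter), small or none beyond the scatter. Compound 4 is estimated at 130 ug/mL, between 55 ug/mL and 220 ug/mL.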

Compound 4, solubility: >= 184 ug/mL
Compound 4 gave a limit, no number (the forecaster's own chance of this, stated with the estimate: 45%); middle value at least 1.4-fold (0.15 log units) away from the limit.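

Compound 4 gives only a limit: the limit of >= 184 ug/mL in this assay, at which 1 of the 4 values shown sits.

With 2,3-dihydro-1H-indol-4-yl in place of 3-methoxyphenyl, the result is an at least 2.3-fold higher number from compound 1 to compound 4 (0.36 log units; beyond the scatter); like 1H-benzimidazol-6-yl, this group clears the scatter, which the floor for cyclohexyl does not. The steps linking compound 4 with compound 2 and compound 3 cannot be read, so no order among these three appears.

Still open, as far as these compounds go, is where the true values of these three compounds lie, and whether an amine or a carboxylic acid on the saturated chain carbon would also reach a limit in this assay.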